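Aryl amide variation in a fused-ring series: cytotoxicity notes

This account rests on a few compounds, and the source may have more. Where it says the series, first, only, none or still open, it means among the compounds named here.

Measured so far:
- Compound 1, `Nc1nn(Cc2cn(CC(=O)Nc3ccc(F)cc3)nn2)c2nc(-c3ccccc3)cc(C(F)(F)F)c12`; in a functional assay on THP-1 cells (Homo sapiens) for cytotoxicity, read by MTT assay, with a stated time of 24 h (a lower number here means a stronger inhibitor, a higher number a weaker inhibitor), compound 1 gives 49.6 ug/mL.
- Compound 2, `Cc1ccc(NC(=O)Cn2cc(Cn3nc(N)c4c(C(F)(F)F)cc(-c5ccccc5)nc43)nn2)cc1`; in this assay compound 2 gives 41.5 ug/mL.

Within the data shown here, compound 2 has the lowest of the two numbers, but its only neighbour is compound 1, and the step of a 1.2-fold lower number from compound 1 to compound 2 (0.08 log units; within the scatter) stays within the scatter, so no order between the two can be read.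

Compound 3, `Nc1nn(Cc2cn(CC(=O)Nc3ccccc3Br)nn2)c2nc(-c3ccccc3)cc(C(F)(F)F)c12`, differs from compound 2 at the aryl amide end: 2-bromophenyl in place of 4-methylphenyl on an amide-type nitrogen. Among the measured compounds shown here, the one measured step, a 1.2-fold lower number from compound 1 to compound 2 (0.08 log units; within the scatter), concerns a different exchange, fluoro to methyl on an aromatic carbon, and no measured pair speaks to the move to a 2-bromophenyl group. The two values in hand show only that the aryl amide substituent has so far left this assay essentially unmoved. The expected step is therefore none beyond the scatter, a 1.1-fold higher number from compound 2 to compound 3 (0.04 log units; within the scatter). Compound 3 is estimated at 45 ug/mL, within a range of 25 ug/mL to 80 ug/mL.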

Compound 3, half-maximal inhibitory concentration: 95.3 ug/mL
The estimate for compound 3 lay 2.1-fold (0.33 log units) below the measured number; the measured number lies above the stated range.
By their numbers in this assay, from the lowest: compounds 2, 1 and 3 (each within the scatter of the next, the first and the last beyond it).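

In this assay, among these compounds, the aryl amide end now registers: 2-bromophenyl in place of 4-methylphenyl on the amide-type nitrogen gives a 2.3-fold higher number from compound 2 to compound 3 (0.36 log units; beyond the scatter) and this modest move is the first step to pass beyond the scatter. Set against the 4-fluorophenyl amide, the same group gives a 1.9-fold higher number from compound 1 to compound 3 (0.28 log units; within the scatter) and that step stays within the scatter, so only compound 2 and compound 3 separate, while compound 1 cannot be ordered against either of them. The exchange leaves the heavy-atom count of the group, its single six-membered aromatic ring and its count of hydrogen-bond donors and acceptors as they were, and nothing in hand bears on why the number moved.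

This one step changes both the substituent and its place on the ring, and the compounds shown do not pull these two apart: 4-bromophenyl and 2-methylphenyl on the same nitrogen would be the pair to do so. Also open, from the compounds shown here alone, is whether the step carries over to groups of another kind at this nitrogen, such as a 4-methoxyphenyl or a cyclohexyl.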